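Aryl switch on the benzylamine of the shared core

The compounds below may be only part of what the source reports. "The series", "measured", "known", "first", "only" and "open" are said of these compounds alone.

Measured so far:
- compound 2 `Cc1ccc(-c2nc3c(N)nc(NCc4cccs4)nc3s2)o1` — 91 nM in a functional assay on CHO cells for agonist activity at adenosine receptor A2b (Homo sapiens), read by scintillation counting and cAMP accumulation, with a stated time of 150 min, in the presence of a further agent that is not named here; on this read-out lower numbers stand for stronger inhibition and higher numbers for weaker inhibition
- compound 1 `COc1cccc(CNc2nc(N)c3nc(-c4ccc(C)o4)sc3n2)c1` — 120 nM in this assay

Compound 2 gives the lowest of the two numbers, with compound 1 next and within the scatter: a 1.3-fold lower number from compound 1 to compound 2 (0.12 log units; within the scatter). Compound 3 `COc1ccccc1CNc1nc(N)c2nc(-c3ccc(C)o3)sc2n1` is not yet measured; it differs from compound 2 by 2-methoxyphenyl in place of thiophen-2-yl on a saturated chain carbon bound to a nitrogen on an aromatic ring. Among the measured compounds shown here, the single step that bears on it, the aryl exchange from compound 1 to compound 2, stayed within the scatter, so no step beyond the scatter is expected in this assay here either. Compound 3 is therefore estimated at 110 nM (range 50 nM to 250 nM), which is expected to mean a 1.2-fold higher number from compound 2 to compound 3 (0.08 log units; within the scatter).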

Compound 3, half-maximal inhibitory concentration: 389 nM
Estimate against measurement, compound 3: 3.5-fold (0.55 log units) below, and the stated range ends below it.
By their numbers in this assay, from the lowest: compounds 2 and 1 (each within the scatter of the next); then compound 3.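

In this assay, among the compounds shown here, the aryl group at this place, on a saturated chain carbon bound to a nitrogen on an aromatic ring, is not freely exchangeable: 2-methoxyphenyl gives a 4.3-fold higher number from compound 2 to compound 3 (0.63 log units; beyond the scatter), the first step beyond the scatter. Exchanging 3-methoxyphenyl for 2-methoxyphenyl gives a 3.2-fold higher number from compound 1 to compound 3 (0.51 log units; beyond the scatter), so a methoxyphenyl group as such does not fix the number. No data on the cause of these steps are at hand.

Still open, going by these compounds, is whether 4-methoxyphenyl reads like compound 1 or like compound 3. Also open, on these data alone, is how a non-aromatic group here, such as cyclohexyl or a longer chain ending in an amine, would read.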